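Chain length on the basic side arm of two cores

A few compounds are considered here, and "the series" means these few. Any claim that something is new, unique, unknown or untested is made for them only; others in the source may bear on it.

Measured so far:
compound 1, `CN(C)CCCn1c(N)c(-c2nc3ccccc3o2)c2nc(C#N)c(C#N)nc21`, 11200 nM
compound 2, `CN(C)CCCCn1c(N)c(-c2nc3ccccc3o2)c2nc(C#N)c(C#N)nc21`, 1950 nM
compound 3, `CN(C)CCn1c(N)c(-c2nc3ccccc3s2)c2nc(C#N)c(C#N)nc21`, > 50000 nM

In a functional assay on HeLa cells (Homo sapiens) for antiproliferative activity, read by MTT assay, with a stated time of 48 h (on this read-out lower numbers stand for stronger inhibition and higher numbers for weaker inhibition), compound 1 gives 11200 nM and compound 2 gives 1950 nM. The change between them is (dimethylamino)methyl in place of dimethylamino on a saturated chain carbon, three bonds along the chain from an aromatic nitrogen, and it yields a 5.7-fold lower number from compound 1 to compound 2 (0.76 log units; beyond the scatter).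

Compound 3 reaches only a limit of the assay, > 50000 nM, so no number is known for it (the limit of > 50000 nM in this assay, at which 1 of the 3 values shown sits). The difference between the core of compound 3 and the core of compound 1 is not broken down here.

Compound 4, `CN(C)CCCn1c(N)c(-c2nc3ccccc3s2)c2nc(C#N)c(C#N)nc21`, is not yet measured. It differs from compound 3 by (dimethylamino)methyl in place of dimethylamino on a saturated chain carbon, two bonds along the chain from an aromatic nitrogen; the place differs from the earlier step, two bonds along the chain rather than three, so this is the same kind of change rather than the same one. Because the earlier lengthening gave a 5.7-fold lower number from compound 1 to compound 2 (0.76 log units; beyond the scatter), a step in the same direction is expected for compound 4, an at least 2.0-fold lower number from compound 3 to compound 4 (0.30 log units; that floor lies within the scatter), though it starts from a limit and so remains uncertain. Compound 4 is therefore estimated at 25000 nM, within 8000 nM to 80000 nM.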

Compound 4, half-maximal inhibitory concentration: 720 nM
For compound 4 the middle estimate is 35-fold (1.54 log units) above the measured one, outside the stated range (below it).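

Across the two cores in this assay, (dimethylamino)methyl in place of dimethylamino lowers the number both times, but the size of the step does not carry over from one core to the other: the same change on two cores in this assay, a 5.7-fold lower number (0.76 log units; beyond the scatter) from compound 1 to compound 2 and an at least 69-fold lower number (1.84 log units; beyond the scatter) from compound 3 to compound 4, at least 12-fold (1.08 log units) apart, beyond the scatter of two such steps

The second of these steps, an at least 69-fold lower number from compound 3 to compound 4 (1.84 log units; beyond the scatter), is only a floor, and its true size remains unknown, since compound 3 stands at a limit and not at a number: the limit of > 50000 nM in this assay, at which 1 of the 4 values shown sits.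

With the side arm unchanged, 1,3-benzothiazol-2-yl in place of 1,3-benzoxazol-2-yl gives a 16-fold lower number from compound 1 to compound 4 (1.19 log units; beyond the scatter), which shows that the core matters in this assay, though two cores cannot show how the change would behave on any other core.

The compounds shown leave open whether a longer chain on the core of compound 4 would lower the number further, as it did between the shorter chains on the core of compound 1. They also leave open what a pyrrolidine or morpholine in place of the dimethylamino group would do on either core.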